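Removing the methyl from the methoxy group of compound 2

The compounds below may be only part of what the source reports. "The series", "measured", "known", "first", "only" and "open" are said of these compounds alone.

Of the compounds shown here, three sharing one core have been measured in a functional assay on HCC 2998 cells (Homo sapiens) for inhibition, read by sulforhodamine B assay, with a stated time of 48 h; a higher number here means a weaker inhibitor of growth, a lower number a stronger inhibitor of growth. Compound 1 `O=C(Nc1cccc(-n2cc(-c3ccncc3)c(-c3ccc(Cl)c(O)c3)n2)c1)Nc1cccc(C(F)(F)F)c1` reaches only the assay limit, giving > 32500 nM, which is a boundary of the assay rather than a number. Compound 3 `COc1cc(-c2nn(-c3cccc(NC(=O)Nc4cccc(C(F)(F)F)c4)c3)cc2-c2ccncc2)ccc1Cl` gives 3200 nM, and compound 2 `COc1cc(-c2nn(-c3cccc(NC(=O)Nc4cc(C(F)(F)F)cc(C(F)(F)F)c4)c3)cc2-c2ccncc2)ccc1Cl` gives 1870 nM, one of the two values reported as numbers; the gap a 1.7-fold higher number from compound 2 to compound 3 (0.23 log units; within the scatter) keeps these two within the usual scatter, so neither can be ranked above the other. Compound 4 `O=C(Nc1cccc(-n2cc(-c3ccncc3)c(-c3ccc(Cl)c(O)c3)n2)c1)Nc1cc(C(F)(F)F)cc(C(F)(F)F)c1` has not yet been measured; it differs from compound 2 by hydrogen in place of methyl on an oxygen on an aromatic ring. The measured step that bears on this is the opposite change, methyl in place of hydrogen on the ring oxygen, which gave an at least 10-fold lower number from compound 1 to compound 3 (1.00 log units; beyond the scatter), limited by the limit of > 32500 nM in this assay, at which 1 of the 3 values shown sits. Reversing that step on compound 2 is therefore expected to give a markedly higher number, a 16-fold higher number from compound 2 to compound 4 (1.21 log units; beyond the scatter), quite possibly again only the limit. Compound 4 is estimated at 30000 nM, between 10000 nM and 90000 nM.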

Compound 4, concentration for total growth inhibition: 2410 nM
Estimate against measurement, compound 4: 12-fold (1.10 log units) above, and the stated range ends above it.
By their numbers in this assay, from the lowest: compounds 2, 4 and 3 (each within the scatter of the next). At a limit, above all of these: compound 1.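

In this assay, going from methoxy to hydroxy on the core of compound 2 gives a 1.3-fold higher number from compound 2 to compound 4 (0.11 log units; within the scatter), so a free hydroxy at this oxygen does not by itself remove growth inhibition. The same change therefore reads differently on the two cores: the same change on two cores in this assay, an at least 10-fold lower number (1.00 log units; beyond the scatter) from compound 1 to compound 3 and a 1.3-fold lower number (0.11 log units; within the scatter) from compound 4 to compound 2, at least 7.8-fold (0.89 log units) apart, beyond the scatter of two such steps. With the hydroxy in place, trifluoromethyl in place of hydrogen on an aromatic carbon gives an at least 13-fold lower number from compound 1 to compound 4 (1.12 log units; beyond the scatter), so what each of these two places does depends on the other: the same change on two cores in this assay, a 1.7-fold higher number (0.23 log units; within the scatter) from compound 2 to compound 3 and an at least 13-fold higher number (1.12 log units; beyond the scatter) from compound 4 to compound 1, at least 7.8-fold (0.89 log units) apart, beyond the scatter of two such steps.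

On these data alone, compound 1 gives > 32500 nM, which is a limit and not a number, so the full size of the gaps that involve it stays open: the limit of > 32500 nM in this assay, at which 1 of the 4 values shown sits. Also open, as far as these compounds go, is how an ethoxy group or an amine in place of the methoxy would read on either core.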